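This account rests on a few compounds, and the source may have more. Where it says the series, first, only, none or still open, it means among the compounds named here.

Measured compounds:

- compound 1, `COc1ccc(S(=O)(=O)N2CCc3cccc(-c4ccc(F)c(F)c4)c32)cc1`: 55.5 nM
- compound 2, `COc1ccc(S(=O)(=O)n2ccc3cccc(-c4ccc(C#N)cc4)c32)cc1`: 143 nM
- compound 3, `COc1ccc(S(=O)(=O)N2CCc3cccc(-c4c(F)c(F)c(F)c(F)c4F)c32)cc1`: 1780 nM

All three numbers come from a functional assay on MKN-45 cells (Homo sapiens) for inhibition, with a stated time of 72 h; on this read-out higher numbers stand for weaker inhibition and lower numbers for stronger inhibition. Among them compound 1 holds the lowest number; compound 2 sits higher by a gap beyond the scatter, and compound 3 sits far higher still, also beyond the scatter. Among the measured compounds shown here, no pair of these three differs in one place only, so no single step between measured compounds can be read off; what can be said is that the compound carrying 3,4-difluorophenyl gives the strongest inhibition seen so far and the one carrying the pentafluorophenyl the weakest.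

Compound 4, `COc1ccc(S(=O)(=O)N2CCc3cccc(-c4cccs4)c32)cc1`, has not yet been measured. It is derived from compound 1 by the change (thiophen-2-yl in place of 3,4-difluorophenyl on an aromatic carbon), the new group standing on the shared core at the same aromatic carbon, ortho to a fused ring.

For the measured compounds named here, with no single-point step available, the expected step from compound 1 to compound 4 is set at a 1.6-fold higher number from compound 1 to compound 4 (0.21 log units; within the scatter), a small move toward weaker inhibition that may well stay within the scatter. The value expected for compound 4 in this assay is 90 nM, with a range from 30 nM to 300 nM.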

Compound 4, half-maximal inhibitory concentration: 165 nM
Compound 4: middle estimate off by 1.8-fold (0.26 log units), on the low side; the measured number falls inside the stated range.
By their numbers in this assay, from the lowest: compound 1; then compounds 2 and 4 (each within the scatter of the next); then compound 3.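

In this assay, the step at this aromatic carbon, ortho to a fused ring, gives the series its first direct reading: thiophen-2-yl in place of 3,4-difluorophenyl produces a 3.0-fold higher number from compound 1 to compound 4 (0.47 log units; beyond the scatter), a modest loss of inhibition. The position therefore responds to the identity of the aromatic group, yet compound 4 still reaches 165 nM, so a six-membered aromatic ring of carbon only is not required here for inhibition in this range. This single step changes the ring size, the hetero atom and the fluorine count together, and no measurement is available that accounts for its size.

Still open, as far as these compounds go, is whether thiophen-3-yl, unsubstituted phenyl or pyridin-3-yl would separate those three changes. From the compounds shown here alone, it is also open whether this carbon accepts a non-aromatic group, such as a morpholine ring or a carboxylic acid on a short chain.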